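Rejoining the amide side chain of compound 2

The source may hold more compounds than are shown below. What is called first, only, known or untested is meant among the compounds shown, and "the series" means these compounds.

Of the compounds shown here, two have been measured so far. For the measured compounds named here, in a physicochemical assay for lipophilicity, measured as octanol-water partition, at pH 7.4 (on this read-out higher numbers stand for higher lipophilicity and lower numbers for lower lipophilicity), compound 2 (`Cc1ccc2[nH]c(C(=O)N[C@H]3CN(S(=O)(=O)c4ccccc4)C[C@@H]3C(=O)NC[C@@H]3CCCN3C)cc2c1`) gives 2.3 and compound 1 (`Cc1ccc2[nH]c(C(=O)N[C@H]3CCN(S(=O)(=O)c4ccccc4)C[C@@H]3C(=O)NCCN(C)C)cc2c1`) gives 2.2 as the only other value. The two numbers lie within the scatter of each other, so compound 2 stands level with compound 1 on this read-out.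

The next structure is compound 3 (`Cc1ccc2[nH]c(C(=O)N[C@H]3CN(S(=O)(=O)c4ccccc4)C[C@@H]3C(=O)N[C@@H]3CCCN(C)C3)cc2c1`), reached from compound 2 by one change (1-methylpiperidin-3-yl in place of (1-methylpyrrolidin-2-yl)methyl on an amide-type nitrogen): 1-methylpiperidin-3-yl in place of (1-methylpyrrolidin-2-yl)methyl on an amide-type nitrogen. The two have the same atoms, joined differently. Going by the values given here, no pair of measured compounds differs in one place only, so the series offers no direct guide to this change. No shift beyond the scatter is expected in this assay for compound 3. The estimated move is small (a number 0.10 log units lower from compound 2 to compound 3 (within the scatter)) and its direction is not firmly expected. For compound 3 the expected reading is 2.2 with an estimated range from 1.8 to 2.6 on this scale.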

Compound 3, distribution coefficient: 2.7
Beside the measured number, compound 3's estimate is 0.50 log units below it, and the stated range ends below it.
By their numbers in this assay, from the lowest: compounds 1 and 2 (each within the scatter of the next); then compound 3.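

In this assay, for the compounds shown here, replacing (1-methylpyrrolidin-2-yl)methyl with 1-methylpiperidin-3-yl on the amide-type nitrogen gives a number 0.40 log units higher from compound 2 to compound 3 (beyond the scatter) and provides the first one-place step. The two groups match in heavy atoms, carbon and nitrogen content, hydrogen-bond donors and acceptors, net charge and defined stereocentres, yet the reading moves, so at this position the way the same atoms are joined is enough to shift the number beyond the scatter. No measurement at hand accounts for the shift.

The change alters the ring from five-membered to six-membered and also removes the (1-methylpyrrolidin-2-yl)methyl connection to the amide-type nitrogen, so this single step cannot separate those two differences, and a 1-methylpyrrolidin-3-yl group at the same place would help to divide them. The compounds shown also leave open whether a 1-methylpiperidin-4-yl group or the opposite stereocentre in 1-methylpiperidin-3-yl would read like compound 3 or would return towards compound 2.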